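This account rests on a few compounds, and the source may have more. Where it says the series, first, only, none or still open, it means among the compounds named here.

In a functional assay on A549 cells (Homo sapiens) for antiproliferative activity, read by MTT assay, with a stated time of 48 h (a lower number here means a stronger inhibitor, a higher number a weaker inhibitor), compound 3, `Cc1ccccc1-n1nncc1CN1C(=O)C2(C(C#N)=C(N)Oc3c(N)cc4nc5ccccc5nc4c32)c2ccccc21`, gives 31700 nM, the lowest of the two actual numbers that this set of compounds has produced. Compound 1, `Cc1cccc(-n2nncc2CN2C(=O)C3(C(C#N)=C(N)Oc4c3c3nc5ccccc5nc3c3ccccc43)c3ccccc32)c1`, gives 39600 nM in this assay, and that number sits within the usual scatter of the number for compound 3, so the two cannot be placed in order. Compound 2, `Cc1ccc(-n2nncc2CN2C(=O)C3(C(C#N)=C(N)Oc4c3c3nc5ccccc5nc3c3ccccc43)c3ccccc32)cc1C`, reaches only a limit of this assay, > 50000 nM, and not a number.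

Compound 4, `N#CC1=C(N)Oc2c(N)cc3nc4ccccc4nc3c2C12C(=O)N(Cc1cnnn1-c1cccc(C(F)(F)F)c1)c1ccccc12`, differs from compound 3 in one place: 3-(trifluoromethyl)phenyl in place of 2-methylphenyl on an aromatic nitrogen. Among the compounds with values here, only one measured step between compounds that differ in a single place exists, and it is an at least 1.2-fold higher number from compound 1 to compound 2 (0.10 log units; that floor lies within the scatter), a small change on the same side ring of the shared core. Within the data shown here, that step is the only guide, and its floor lies within the scatter, so the change from compound 3 to compound 4 is expected to give no step beyond the scatter in this assay, in either direction. Compound 4 is therefore expected to give about 35000 nM in this assay, with a range from 12000 nM to 100000 nM. That estimate means a step of a 1.1-fold higher number from compound 3 to compound 4 (0.04 log units; within the scatter), and a fair chance remains that only a limit is reported.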

Compound 4, half-maximal inhibitory concentration: 5400 nM
The estimate for compound 4 lay 6.5-fold (0.81 log units) above the measured number; the whole stated range lies above it.
By their numbers in this assay, from the lowest: compound 4; then compounds 3 and 1 (each within the scatter of the next). At a limit, above all of these: compound 2.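

In this assay, within the data shown here, the group on the aromatic nitrogen of the five-membered ring turns out to matter: a 5.9-fold lower number from compound 3 to compound 4 (0.77 log units; beyond the scatter) is the first step in this set that lies beyond the scatter. Among these compounds, the only earlier step, an at least 1.2-fold higher number from compound 1 to compound 2 (0.10 log units; that floor lies within the scatter), has a floor within the scatter and so gave no sign that changes on this side ring could move the number at all. The new step also involves two changes at once, since going from 2-methylphenyl to 3-(trifluoromethyl)phenyl alters both the substituent and its place on the phenyl ring, and nothing measured here says why the number moved.

Which of those two changes carries the step stays open, and a 3-methylphenyl or a 2-(trifluoromethyl)phenyl group on the core of compound 3 would pull them apart. Also open, as far as these compounds go, are whether other groups at the same place on the phenyl ring, such as chloro, methoxy or an amine, would give a step of similar size, and whether 3-(trifluoromethyl)phenyl would do the same on the core of compound 1.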